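Clearance notes: side chain entering the phenoxy amide series

This account rests on a few compounds, and the source may have more. Where it says the series, first, only, none or still open, it means among the compounds named here.

Three compounds of the shared core have numbers in an ADME assay on the whole organism (Mus musculus, strain CD1) for pharmacokinetics, read by LC-MS, using cassette dosing, with a stated time of 24 h, at a dose of 0.4 mg/kg by the intravenous route; on this read-out higher numbers stand for fast clearance and lower numbers for slow clearance. Compound 1 `Cc1cn(-c2cc(NC(=O)c3ccc(C)c(Nc4nccc(-c5ccccc5)n4)c3)cc(N3CCNCC3)c2)cn1` gives 52.5 mL/min/kg, compound 2 `Cc1cn(-c2cc(CN3CCN(C)CC3)cc(NC(=O)c3ccc(C)c(Nc4nccc(-c5ccccc5)n4)c3)c2)cn1` gives 35.7 mL/min/kg, and compound 3 `Cc1cn(-c2cc(NC(=O)c3ccc(C)c(Oc4ccccc4)c3)cc(C(F)(F)F)c2)cn1` gives 12.5 mL/min/kg, the lowest of the three; the nearest, compound 2, stands well beyond the scatter above it. Among the compounds with values here, the one measured step, a 1.5-fold lower number from compound 1 to compound 2 (0.17 log units; within the scatter), swaps one side chain for another and stays within the scatter, so it says little about the change at hand. Compound 4 `Cc1cn(-c2cc(CN3CCC[C@H](N)C3)cc(NC(=O)c3ccc(C)c(Oc4ccccc4)c3)c2)cn1` differs from compound 3 by (3-aminopiperidin-1-yl)methyl in place of trifluoromethyl on an aromatic carbon. Within the data shown here, no measured pair isolates this swap; what can be said is that compound 1, carrying a nitrogen-containing side chain at this position, sits at 52.5 mL/min/kg, compound 2, carrying one as well, sits at 35.7 mL/min/kg, while compound 3 without one sits at 12.5 mL/min/kg. An upward step is therefore expected for compound 4, estimated as a 2.4-fold higher number from compound 3 to compound 4 (0.38 log units; beyond the scatter), with wide uncertainty since the rest of the molecule also differs from compounds 1 and 2. Compound 4 is expected near 30 mL/min/kg, within 14 mL/min/kg to 65 mL/min/kg.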

Compound 4, clearance: 5 mL/min/kg
Beside the measured number, compound 4's estimate is 6.0-fold (0.78 log units) above it; measured number outside the range, below it.
By their numbers in this assay, from the lowest: compound 4; then compound 3; then compounds 2 and 1 (each within the scatter of the next).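

In this assay, within the data shown here, (3-aminopiperidin-1-yl)methyl in place of trifluoromethyl on this aromatic carbon gives a 2.5-fold lower number from compound 3 to compound 4 (0.40 log units; beyond the scatter), the first step that isolates a change at this position on the phenoxy amide core. It shows that, on this core, a side chain containing a six-membered non-aromatic ring and an amine can replace trifluoromethyl here with a lower clearance number, not a higher one. Nothing available bears on why the number falls.

Still open, from the compounds shown here alone, is whether the amine or the ring carries the step, a question that plain piperidin-1-ylmethyl or morpholin-4-ylmethyl at this place would address. Going by these compounds, the opposite configuration at the stereocentre also remains open, as does the effect of a carboxylic acid on the piperidine ring in place of the amine.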